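Methoxy to trifluoromethoxy at a reporting limit

This account rests on a few compounds, and the source may have more. Where it says the series, first, only, none or still open, it means among the compounds named here.

- compound 1 `CC(=O)Oc1ccc(/C=C/c2ccc3ccccc3c2)cc1` gives > 5000 nM, a limit
- compound 2 `COc1ccc(/C=C/c2ccc3ccccc3c2)cc1` gives > 5000 nM, a limit

Compound 2 reaches only a limit in a functional assay on SK-MEL-28 cells (Homo sapiens) for inhibition (on this read-out higher numbers stand for weaker inhibition and lower numbers for stronger inhibition), at > 5000 nM. Compound 3 `FC(F)(F)Oc1ccc(/C=C/c2ccc3ccccc3c2)cc1` differs from it by one change: trifluoromethyl in place of methyl on an oxygen on an aromatic ring. Going by the values given here, the only measured step that bears on this, a step that the two limits leave unreadable from compound 1 to compound 2, falls on the same oxygen, but the limit of > 5000 nM in this assay, at which 2 of the 2 values shown sit, shows that it has no readable size. It therefore offers no size or direction to carry over, and no clear move in this assay is expected. The expected step is a step that the limit leaves unreadable from compound 2 to compound 3, a rough estimate. For compound 3 the estimated value is 8000 nM, with an expected range of 3000 nM to 20000 nM.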

Compound 3, half-maximal inhibitory concentration: > 5000 nM
Compound 3: a limit, no number (the forecaster's own chance of this, stated with the estimate: 80%); the middle value is on the limit's open side.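

Compound 3 gives > 5000 nM, a limit, so the steps to it from compound 1 and compound 2 cannot be read. The compounds shown leave open whether these three differ at all in this assay.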